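Pyrimidin-2-yl for oxetan-3-yl on the ring amine

This account rests on a few compounds, and the source may have more. Where it says the series, first, only, none or still open, it means among the compounds named here.

Measured so far in an in vitro ADME assay on microsomes from liver (Mus musculus) for pharmacokinetics, read by LC-MS, with a stated time of 10 min, tested at 1 uM; on this read-out lower numbers stand for slow clearance and higher numbers for fast clearance 
- Compound 1 `CN1C[C@H](C(=O)Nc2ccc(Br)cc2)[C@@H](c2ccc(/C=C/C(=O)Nc3ccccc3N)cc2)C1` gives 16 mL/min/kg 
- Compound 2 `CN1C[C@H](C(=O)Nc2ccc(F)c(Br)c2)[C@@H](c2ccc(/C=C/C(=O)Nc3ccccc3N)cc2)C1` gives 43 mL/min/kg 
- Compound 3 `Nc1ccccc1NC(=O)/C=C/c1ccc([C@H]2CN(C3COC3)C[C@@H]2C(=O)Nc2ccc(Cl)cc2)cc1` gives 42 mL/min/kg 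

Compound 3 lies within the scatter of compound 2 and beyond the scatter above compound 1, so it belongs to the upper pair of the three. Compound 4 `Nc1ccccc1NC(=O)/C=C/c1ccc([C@H]2CN(c3ncccn3)C[C@@H]2C(=O)Nc2ccc(Cl)cc2)cc1` differs from compound 3 in one place. The change is pyrimidin-2-yl in place of oxetan-3-yl on an amine nitrogen in a ring and it sits on an amine nitrogen in a ring. Among the measured compounds shown here, the only measured step with a single change is a 2.7-fold higher number from compound 1 to compound 2 (0.43 log units; beyond the scatter) and it is modest, but it lies on an amide-type nitrogen and says nothing direct about this position. Compound 1 and compound 3 differ in more than one place, so their gap isolates no single change. For the measured compounds named here, no measured step replaces the group on the amine nitrogen, so no direction is expected in this assay and no shift beyond the scatter. The expectation therefore stays anchored on compound 3 with 42 mL/min/kg as its starting point. The expected change is a 1.1-fold higher number from compound 3 to compound 4 (0.03 log units; within the scatter) as an estimate only. For compound 4 the estimated clearance is 45 mL/min/kg with an expected range from 20 mL/min/kg to 95 mL/min/kg in this assay.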

Compound 4, clearance: 44 mL/min/kg
For compound 4 the middle estimate is 1.0-fold (0.01 log units) above the measured one, and the stated range covers the measured number.
By their numbers in this assay, from the lowest: compound 1; then compounds 3, 2 and 4 (each within the scatter of the next).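

In this assay, the first step measured on this amine nitrogen in a ring gives a 1.0-fold higher number from compound 3 to compound 4 (0.02 log units; within the scatter). With the (4-chlorophenyl)carbamoyl group held constant, a six-membered aromatic ring thus takes the place of a four-membered non-aromatic ring with no change beyond the scatter, so this exchange at this position leaves the clearance number where it was. Nothing measured here offers an explanation for that result.

Methyl on this nitrogen appears only with a different group on the amide, so its effect relative to oxetan-3-yl or pyrimidin-2-yl cannot be read from the compounds shown. On these data alone, it also remains open whether an acetyl group, a methylsulfonyl group or a simple hydrogen on this nitrogen would give a number beyond the scatter of these two compounds.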